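Notes on the step from compound 2 to compound 3

The compounds below may be only part of what the source reports. "The series", "measured", "known", "first", "only" and "open" are said of these compounds alone.

Measured so far in an assay on membranes from heart (Canis lupus familiaris) for displacement of a labelled ligand from sulfonylurea receptor 2, Kir6.2 (Homo sapiens); a lower number here means a stronger inhibitor, a higher number a weaker inhibitor:
- compound 1, `CCC(C)(C)/N=C(\NC#N)Nc1ccc(I)cc1`, gives 74 nM
- compound 2, `CC(C)(C)/N=C(\NC#N)Nc1ccc(C#N)cc1`, gives 480 nM

Compound 2 stands at the higher of the two numbers in this assay, which makes it the weaker binder of the pair, and the gap to compound 1 lies beyond the scatter. For the measured compounds named here, compound 1 and compound 2 differ in two places at once, so no single step between them can be read off; only the two values themselves are known.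

Compound 3, `C/N=C(\NC#N)Nc1ccc(C#N)cc1`, differs from compound 2 in one place: methyl in place of tert-butyl on a double-bonded nitrogen. Going by the values given here, no measured pair covers a change of this kind, so the size of the step rests on expectation alone. The tert-butyl group is the larger of the two alkyl groups on this nitrogen, and the expectation is that its replacement by methyl moves the number upward in this assay, that is toward weaker binding, by a step that is clearly beyond the scatter. Compound 3 is thus expected to give 3000 nM in this assay, within a range from 800 nM to 12000 nM. The expected step of a 6.3-fold higher number from compound 2 to compound 3 (0.80 log units; beyond the scatter) is an estimate, not a measurement.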

Compound 3, inhibition constant: > 30000 nM
Compound 3 was reported as a limit; the forecaster's own chance of this, stated with the estimate: 15%; at least 10-fold (1.00 log units) between middle value and limit.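

In this assay, for the compounds shown here, the first step that can be read at a single place is an at least 62-fold higher number from compound 2 to compound 3 (1.79 log units; beyond the scatter), for methyl in place of tert-butyl on a double-bonded nitrogen. Compound 3 gives > 30000 nM, which is a limit of the assay and not a number: the limit of > 30000 nM in this assay, at which 1 of the 3 values shown sits. The earlier pair differs in two places at once and could not isolate this position, whereas this step shows that the alkyl group here on its own has a large bearing on the number, with the rest of the structure held constant.

The compounds shown leave open how the number moves between these two groups, and whether an ethyl or isopropyl group on this nitrogen would sit close to tert-butyl or close to methyl. Also open, as far as these compounds go, is whether a cyclohexyl group or a longer chain such as n-pentyl would go further than tert-butyl, and whether the same step would appear on the core of compound 1.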